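The source may hold more compounds than are shown below. What is called first, only, known or untested is meant among the compounds shown, and "the series" means these compounds.

Working notes on the series.

Compound 1 `CO[C@@H]1CC=C2NN(c3cc4ccccc4[nH]3)C(=O)C[C@]2(C)O1` is the reference point. In a functional assay on SK-BR-3 cells (Homo sapiens) for inhibition, read by sulforhodamine B assay, with a stated time of 48 h (a higher number here means a weaker inhibitor, a lower number a stronger inhibitor), compound 1 gives 4100 nM. Compound 2 `CO[C@@H]1CC=C2NN(c3cc4ccccc4[nH]3)C(=O)C[C@]2(c2ccccc2)O1` carries a single change relative to compound 1, (phenyl in place of methyl on a saturated ring carbon), and in this assay compound 2 gives 530 nM. For the measured compounds named here, the step of a 7.7-fold lower number from compound 1 to compound 2 (0.89 log units; beyond the scatter) is the only measured step in the set so far, and it stands beyond the usual scatter.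

Compound 3 `CO[C@@H]1CC=C2NN(c3cncnc3)C(=O)C[C@]2(C)O1` has a different core from compound 1; the difference between the two cores is not broken down here. In this assay compound 3 gives 3400 nM, a value that sits within the scatter of the value for compound 1, so no ordering of compound 1 and compound 3 is drawn from these two numbers. Against compound 2 the gap is larger, with compound 2 the lower number of the pair.

Compound 4 `CO[C@@H]1CC=C2NN(c3cncnc3)C(=O)C[C@]2(c2ccccc2)O1` is not yet measured. It relates to compound 3 by phenyl in place of methyl on a saturated ring carbon, and the place of this change is described in the same words as for the change from compound 1 to compound 2, so it is the same change on a second core. Going by the values given here, with only one prior instance, any expectation rests on that single step. The expected step is a 6.2-fold lower number from compound 3 to compound 4 (0.79 log units; beyond the scatter), set beside a 7.7-fold lower number from compound 1 to compound 2 (0.89 log units; beyond the scatter), on the assumption that the change carries over to the core of compound 3 in roughly the same size, with a wider range to allow for the untested core. Compound 4 is estimated at 550 nM, expected to fall between 200 nM and 1600 nM.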

Compound 4, half-maximal inhibitory concentration: 5300 nM
Beside the measured number, compound 4's estimate is 9.6-fold (0.98 log units) below it; the whole stated range lies below it.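

In this assay, the replacement of methyl by phenyl on the saturated ring carbon does not carry over from the core of compound 1 to the core of compound 3 at the same size: the same change on two cores in this assay, a 7.7-fold lower number (0.89 log units; beyond the scatter) from compound 1 to compound 2 and a 1.6-fold higher number (0.19 log units; within the scatter) from compound 3 to compound 4, 12-fold (1.08 log units) apart, beyond the scatter of two such steps

The step of a 1.6-fold higher number from compound 3 to compound 4 (0.19 log units; within the scatter) leaves the two pyrimidin-5-yl compounds unresolved, whereas among the phenyl compounds, pyrimidin-5-yl in place of 1H-indol-2-yl on the amide-type nitrogen in a ring gives a 10-fold higher number from compound 2 to compound 4 (1.00 log units; beyond the scatter). The result shows that the step seen with phenyl in the 1H-indol-2-yl pair cannot be assumed on the second core, but with one pair per core it does not show why the two steps part, nor how the change would behave on any further core.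

Going by these compounds, it remains open whether another group on the saturated ring carbon, such as benzyl or a longer alkyl chain, would show the same split between the two cores. On these data alone, it is also open whether a plain phenyl or a pyridin-3-yl group on the amide-type nitrogen in a ring would follow the 1H-indol-2-yl pair or the pyrimidin-5-yl pair.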